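This account rests on a few compounds, and the source may have more. Where it says the series, first, only, none or still open, it means among the compounds named here.

In an assay on CHO cells for displacement of a labelled ligand from adenosine receptor A3 (Homo sapiens), read by scintillation counting, tested at 10 uM (a higher number here means more inhibition at the concentration tested (going by the name of the read-out), a lower number less inhibition), the three measured compounds read as follows: compound 1 `CC(C)(C)Cc1c(-c2ccncc2)sc(N)c1C(=O)c1ccc(Cl)cc1` gives 6%; compound 2 `CC(C)(C)Cc1c(-c2cccnc2)sc(N)c1C(=O)c1ccc(Cl)cc1` gives 1%; compound 3 `CC(C)(C)Cc1c(-c2ccccn2)sc(N)c1C(=O)c1ccc(Cl)cc1` gives 1%.

Compound 3 stands level with compound 2 at the digits shown, and together they are the lowest of the three; the gap to compound 1 is the step of a number 5 percentage points lower from compound 1 to compound 3 (within the scatter), which lies within the scatter.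

Compound 4 `CC(C)(C)Cc1c(-c2cccc(F)c2F)sc(N)c1C(=O)c1ccc(Cl)cc1` differs from compound 3 by 2,3-difluorophenyl in place of pyridin-2-yl on an aromatic carbon. The measured steps of a number 5 percentage points lower from compound 1 to compound 2 (within the scatter), a number 5 percentage points lower from compound 1 to compound 3 (within the scatter) and no change at the digits printed from compound 2 to compound 3 (within the scatter) each exchange one pyridinyl for another and all stay within the scatter; none of them brings in a difluorophenyl, so they bear on this change only loosely. With every value near the bottom of the scale, no step beyond the scatter in this assay is expected in either direction. Compound 4 is therefore estimated at 5%, between 0% and 20%, an expected step of a number 4 percentage points higher from compound 3 to compound 4 (within the scatter).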

Compound 4, a percentage reported as inhibition, at one concentration (the size of the read-out at that concentration, not a potency): 1%
Compound 4: middle estimate off by 4 percentage points, on the high side, and the stated range covers the measured number.
By their numbers in this assay, from the lowest: compounds 2, 3, 4 and 1 (each within the scatter of the next).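

In this assay, putting 2,3-difluorophenyl, a carbon-only ring with no hydrogen-bond acceptor, on the carbon next to the ring sulfur gives no change at the digits printed from compound 3 to compound 4 (within the scatter) and no change at the digits printed from compound 2 to compound 4 (within the scatter) and a number 5 percentage points lower from compound 1 to compound 4 (within the scatter). Leaving the pyridinyl rings for this fluorinated ring therefore keeps the reading in the same low band as swapping one pyridinyl for another. Nothing measured here offers an explanation for this reading.

From the compounds shown here alone, whether any group at this position can lift the number beyond the scatter stays open, for instance a carboxylic acid or a piperidine ring. Also open, going by these compounds, is how the reading responds when the neopentyl group gives way to a shorter chain such as ethyl.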